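Swapping cyclohexyl for hydrogen in a stability series

The compounds below may be only part of what the source reports. "The series", "measured", "known", "first", "only" and "open" are said of these compounds alone.

Of the compounds shown here, three have been measured so far in an ADME assay on microsomes from liver (Homo sapiens) for metabolic stability, read by LC-MS, with a stated time of 10 min; on this read-out lower numbers stand for a less stable compound and higher numbers for a more stable compound. Compound 1 `CN(C[C@H]1Cc2c(cccc2N2CCN(C3CC3)CC2)CN1)[C@H]1CCCc2cccnc21` gives 15.5%, compound 2 `CN(C[C@H]1Cc2c(cccc2N2CCNC(C)(C)C2)CN1)[C@H]1CCCc2cccnc21` gives 100%, and compound 3 `c1cnc2c(c1)CCC[C@@H]2N(CC1CCCCC1)C[C@H]1Cc2c(cccc2N2CCNCC2)CN1` gives 81.6%. That puts compound 3 second of the three, under compound 2 and far over compound 1, with both gaps beyond the usual scatter.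

Next comes compound 4 `CN(C[C@H]1Cc2c(cccc2N2CCNCC2)CN1)[C@H]1CCCc2cccnc21`. It differs from compound 3 by hydrogen in place of cyclohexyl on a saturated chain carbon bound to an amine nitrogen. In words, this is hydrogen in place of cyclohexyl on a saturated chain carbon bound to an amine nitrogen, so cyclohexylmethyl becomes methyl.

For the measured compounds named here, the only measured step between two compounds is a number 84.5 percentage points higher from compound 1 to compound 2 (beyond the scatter). It is large, but it concerns a group on an aromatic carbon, so no measurement shows the present change directly. Compound 4 carries the same methyl as compound 1 and compound 2, and those two sit at opposite ends of the numbers. The methyl alone therefore settles little. Compound 4 keeps the aromatic-carbon group of compound 3, which gives 81.6%, and that value is the best starting point. The expected step is small and upward, a number 6.4 percentage points higher from compound 3 to compound 4 (within the scatter), and probably stays within the scatter. For compound 4 the estimated value is 88%, with an expected range from 68% to 100%.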

Compound 4, percent of the compound remaining: 99.7%
The estimate for compound 4 lay 11.7 percentage points below the measured number; the measured number falls inside the stated range.
By their numbers in this assay, from the lowest: compound 1; then compound 3; then compounds 4 and 2 (each within the scatter of the next).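

Cutting cyclohexylmethyl back to methyl gives a number 18.1 percentage points higher from compound 3 to compound 4 (beyond the scatter) in this assay, so the group on this saturated chain carbon does change the read-out, and the smaller group goes with more of the compound remaining. With methyl in place on the chain, the two ring groups on the aromatic carbon cannot be told apart: piperazin-1-yl in place of 3,3-dimethylpiperazin-1-yl gives a number 0.3 percentage points lower from compound 2 to compound 4 (within the scatter). The cyclopropyl on the ring amine nitrogen matters far more than the chain change, since hydrogen in its place gives a number 84.2 percentage points higher from compound 1 to compound 4 (beyond the scatter), and nothing at hand explains why either of these changes moves the number.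

Only cyclohexylmethyl and methyl are shown on this amine nitrogen, so it remains open whether the number falls gradually with size or only with a ring, which an ethyl, a longer chain or a cyclopropylmethyl group could help to separate. Going by these compounds, it is also open whether a small group such as methyl or ethyl on the ring amine nitrogen would cost as much as cyclopropyl does.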